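The compounds below may be only part of what the source reports. "The series", "measured", "known", "first", "only" and "open" are said of these compounds alone.

Measured so far:
- compound 1 `Cc1ccc2[nH]c(=O)c(CN(Cc3ccc(C(C)(C)C)cc3)C(C)c3ccc(N(C)C)c(Cl)c3)cc2c1`: 9800 nM in a toxicity assay on MDCK cells (Canis lupus familiaris) for cytotoxicity, read by crystal violet staining, with a stated time of 48 h; a higher number here means that more compound is tolerated, a lower number that less compound is tolerated
- compound 2 `COc1ccc(C(C)N(Cc2ccc(C(C)(C)C)cc2)Cc2cc3cc(C)ccc3[nH]c2=O)cc1Cl`: in this assay compound 2 is reported only as a limit, > 10000 nM
- compound 3 `CC(c1ccc(N(C)C)c(Cl)c1)N(Cc1ccc(C(C)(C)C)cc1)Cc1cc2cc(Br)ccc2[nH]c1=O`: in this assay compound 3 gives 6100 nM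

Compound 1 and compound 2 differ in one place (methoxy in place of dimethylamino on an aromatic carbon), and that step reads an at least 1.0-fold higher number from compound 1 to compound 2 (0.00 log units; that floor lies within the scatter), with the limit of > 10000 nM in this assay, at which 1 of the 3 values shown sits, the ceiling of the measurement.

The two cores differ in one place (bromo in place of methyl on an aromatic carbon), and that step reads a 1.6-fold lower number from compound 1 to compound 3 (0.21 log units; within the scatter).

Compound 4 `COc1ccc(C(C)N(Cc2ccc(C(C)(C)C)cc2)Cc2cc3cc(Br)ccc3[nH]c2=O)cc1Cl` carries the same change made on the core of compound 3 (methoxy in place of dimethylamino on an aromatic carbon), the surroundings of the changed place being the same as in compound 2. The step is expected to be about a 1.5-fold higher number from compound 3 to compound 4 (0.17 log units; within the scatter), resting on the earlier step of an at least 1.0-fold higher number from compound 1 to compound 2 (0.00 log units; that floor lies within the scatter) and on the starting value of compound 3. Compound 4 is therefore estimated at 9000 nM, between 4500 nM and 20000 nM.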

Compound 4, half-maximal cytotoxic concentration: > 10000 nM
Compound 4: no number, only a limit; the forecaster's own chance of this, stated with the estimate: 40%; middle value at least 1.1-fold (0.04 log units) away from the limit.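

In this assay, changing dimethylamino to methoxy on the core that carries bromo gives an at least 1.6-fold higher number from compound 3 to compound 4 (0.21 log units; that floor lies within the scatter). Both this step and the matching step on the core that carries methyl are only floors, so the data are compatible with the change carrying over between cores but do not show that it does, or how large it is on either core: the same change on two cores in this assay, an at least 1.0-fold higher number (0.00 log units; that floor lies within the scatter) from compound 1 to compound 2 and an at least 1.6-fold higher number (0.21 log units; that floor lies within the scatter) from compound 3 to compound 4; the limit leaves it open whether they differ Compound 2 and compound 4 are both reported only as limits, so the step from bromo to methyl between them cannot be read: the limit of > 10000 nM in this assay, at which 2 of the 4 values shown sit.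

On these data alone, the true values of compound 2 and compound 4 remain open. So does what a carboxylic acid or ethoxy would give in place of methoxy.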